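This account rests on a few compounds, and the source may have more. Where it says the series, first, only, none or still open, it means among the compounds named here.

Compounds measured so far: compound 1 `Cn1ccc2ccc(-c3cc(Nc4cnccc4C(=O)NCc4cncnc4)cc4nccnc34)cc21` with 49500 nM; compound 2 `CC(=O)N1CCCC(NC(=O)c2ccncc2Nc2cc(-c3ccc4ccn(C)c4c3)c3nccnc3c2)C1` with 13500 nM.

Going by the values given here, in an assay on lysate for inhibition of 6-phosphofructo-2-kinase/fructose-2,6-bisphosphatase 3 (Homo sapiens), with stated times of 0.5 min and 45 min (a lower number here means a stronger inhibitor, a higher number a weaker inhibitor), compound 2 has the lowest of the two numbers so far; its nearest neighbour is compound 1, the only other measured compound, and the gap between the two is a 3.7-fold lower number from compound 1 to compound 2 (0.56 log units; beyond the scatter), a modest step that lies beyond the scatter. That step replaced the (pyrimidin-5-yl)methyl of compound 1 with the 1-acetylpiperidin-3-yl of compound 2 on the amide-type nitrogen.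

Compound 3 `Cn1ccc2ccc(-c3cc(Nc4cnccc4C(=O)NCC4COCCN4)cc4nccnc34)cc21` is not yet measured. It differs from compound 2 by (morpholin-3-yl)methyl in place of 1-acetylpiperidin-3-yl on an amide-type nitrogen. Among the compounds with values here, the one measured step touches the same amide-type nitrogen but swaps a different pair of groups, so it says only that this position tolerates change of the order seen from compound 1 to compound 2, without fixing a direction for the present swap. No step beyond the scatter in this assay is therefore expected from compound 2 to compound 3, and the expected step is put at a 1.3-fold higher number from compound 2 to compound 3 (0.12 log units; within the scatter). On that basis compound 3 is estimated at 18000 nM in this assay, with a range from 6000 nM to 50000 nM.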

Compound 3, half-maximal inhibitory concentration: 41700 nM
Compound 3: the middle estimate sits 2.3-fold (0.36 log units) below what was measured, within the range that was stated.
By their numbers in this assay, from the lowest: compound 2; then compounds 3 and 1 (each within the scatter of the next).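

In this assay, the amide-type nitrogen proves sensitive to this exchange of groups, with a 3.1-fold higher number from compound 2 to compound 3 (0.49 log units; beyond the scatter), so the gain earlier seen with 1-acetylpiperidin-3-yl does not carry over to (morpholin-3-yl)methyl. With the methyl chain held and morpholin-3-yl in place of pyrimidin-5-yl on the saturated chain carbon, the result is a 1.2-fold lower number from compound 1 to compound 3 (0.07 log units; within the scatter), so this ring exchange gives no step beyond the scatter, and of the three compounds only compound 2 stands apart from the others. No measurement shown here accounts for the separation of compound 2 from compound 3.

The step from compound 2 to compound 3 changes the ring, the acetyl group and the attachment through a methyl chain all at once, so the compounds shown do not say which of these carries the difference. A (1-acetylpiperidin-3-yl)methyl group or an unacetylated piperidin-3-yl on the same nitrogen would begin to separate these contributions, and a 4-acetylmorpholin-3-yl-methyl group would test the acetyl group on the morpholine ring.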